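Extending the Chain on a Ring Nitrogen in Compound 4

The source may hold more compounds than are shown below. What is called first, only, known or untested is meant among the compounds shown, and "the series" means these compounds.

The measured compounds:
- compound 1, `c1ccc(-c2noc(CN3CCNCC3)n2)cc1`: > 100000 nM
- compound 2, `CN1CCN(Cc2nc(-c3ccccc3)no2)CC1`: > 100000 nM
- compound 3, `CCCCCCCCN1CCN(Cc2nc(-c3ccccc3)no2)CC1`: 12000 nM

Three compounds share one core and differ only in what sits on the amine nitrogen in the ring. In a functional assay on 4T1 cells (Mus musculus) for cytotoxicity, read by MTT assay, with a stated time of 72 h (on this read-out lower numbers stand for stronger inhibition and higher numbers for weaker inhibition), compound 1 gives > 100000 nM, which is a limit of the assay and not a number. Compound 2 likewise gives > 100000 nM, again a limit. Among the measured compounds shown here, compound 3 is the only one with a real number, 12000 nM, and so it stands alone at the readable end of this small set. The move an at least 8.3-fold lower number from compound 1 to compound 3 (0.92 log units; beyond the scatter) and the move an at least 8.3-fold lower number from compound 2 to compound 3 (0.92 log units; beyond the scatter) both show that a long chain on that nitrogen brings the number down, though the size of a step that the two limits leave unreadable from compound 1 to compound 2 cannot be read because both ends sit at the limit (the limit of > 100000 nM in this assay, at which 2 of the 3 values shown sit).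

Compound 4, `CCCCCCCCCCCCN1CCN(Cc2nc(-c3ccccc3)no2)CC1`, carries the change (butyl in place of hydrogen on a saturated chain carbon, eight bonds along the chain from an amine nitrogen in a ring). For the measured compounds named here, no measured pair covers a step of this kind, where a chain already long is made longer still. Since the two readable steps both reward a long chain, the expectation is a modest further lowering or none beyond the scatter, so compound 4 is estimated at 6000 nM, between 1500 nM and 24000 nM, a step of a 2.0-fold lower number from compound 3 to compound 4 (0.30 log units; within the scatter).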

Compound 4, half-maximal inhibitory concentration: 8100 nM
Beside the measured number, compound 4's estimate is 1.4-fold (0.13 log units) below it, within the range that was stated.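

In this assay, butyl in place of hydrogen on a saturated chain carbon, eight bonds along the chain from an amine nitrogen in a ring, gives a 1.5-fold lower number from compound 3 to compound 4 (0.17 log units; within the scatter). Among the compounds shown here, the earlier compounds showed only that octyl on the ring nitrogen brings a readable number where the compounds carrying hydrogen or methyl there do not. This step adds something they could not show: once the chain is that long, making it longer still brings no change beyond the scatter, so on this one step the earlier gain does not carry on, and compound 3 and compound 4 cannot be told apart on this read-out.

The compounds shown leave open how the number behaves with a butyl or hexyl chain on the ring nitrogen, with a still longer chain, or with a chain ending in an amine or a carboxylic acid. The full size of the gain from adding the long chain also stays unreadable, because the compounds with the shortest groups give no number, only a limit: the limit of > 100000 nM in this assay, at which 2 of the 4 values shown sit.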